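Extending the selenium-bound chain of compound 1

The source may report more compounds than this note shows. Statements on the series, on what has been measured and on what is new or still open speak of the compounds shown alone.

Measured so far:
- compound 1, `C[Se]c1nc(N)c2ccccc2n1`: in a functional assay on CCRF-CEM cells (Homo sapiens) for cytotoxicity, read by MTT assay, with a stated time of 72 h (a lower number here means that less compound is tolerated, a higher number that more compound is tolerated), compound 1 gives > 100000 nM, a limit of the assay
- compound 2, `C[Se]c1nc([Se]C)c2ccccc2n1`: in this assay compound 2 gives 78500 nM

Compound 1 stands at the limit of the assay, (the limit of > 100000 nM in this assay, at which 1 of the 2 values shown sits), so no number is known for it. Compound 3, `CCCCC[Se]c1nc(N)c2ccccc2n1`, differs from compound 1 by butyl in place of hydrogen on a saturated chain carbon bound to a selenium atom. Among the measured compounds shown here, the single measured step, an at least 1.2-fold lower number from compound 1 to compound 2 (0.10 log units; that floor lies within the scatter), changes a different group and gives little guidance on lengthening the chain. Compound 3 is therefore expected to stay near that limit, the estimated step being an at least 1.6-fold lower number from compound 1 to compound 3 (0.22 log units; that floor lies within the scatter). The estimate for compound 3 is 60000 nM, with a range from 15000 nM to 200000 nM.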

Compound 3, concentration lethal to 50% of the cells: > 100000 nM
Compound 3 gave a limit, no number; the forecaster's own chance of this, stated with the estimate: 45%; at least 1.6-fold (0.22 log units) between middle value and limit.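

Among the compounds shown here, compound 1 and compound 3 both give a limit rather than a number, so no step between them can be read: the limit of > 100000 nM in this assay, at which 2 of the 3 values shown sit. The compounds shown leave open whether going from methyl to pentyl on the selenium changes cytotoxicity at all.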